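A few compounds are considered here, and "the series" means these few. Any claim that something is new, unique, unknown or untested is made for them only; others in the source may bear on it.

Working notes on the solubility series.

Compound 1 `COc1ccc2[nH]c(C(=O)N3CC(=O)N(Cc4ccccc4)[C@@H](CN4CCC5(CC4)CC5)C3)cc2c1` is the reference point. In a physicochemical assay for solubility, read by spectrophotometry, in phosphate buffer, with a stated time of 2 h, at pH 7.4 (a lower number here means a less soluble compound, a higher number a more soluble compound), compound 1 gives 28200 nM, the highest of the three numbers in hand. Compound 3 `COc1cccc(CN2C(=O)CN(C(=O)c3cc4cc(OC)ccc4[nH]3)C[C@@H]2CC2CCCCC2)c1` sits nearest to it: in this assay compound 3 gives 21400 nM, a gap that falls within the usual scatter, so the two cannot be ordered. Compound 2 `O=C(c1cc2cc(C3CC3)ccc2[nH]1)N1CC(=O)N(Cc2ccccc2)[C@@H](CN2CCN(Cc3ccccc3)CC2)C1` stands furthest away: in this assay compound 2 gives 12900 nM, a number lower than that of compound 1 by a margin beyond the scatter.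

Compound 4 `COc1ccc2[nH]c(C(=O)N3CC(=O)N(Cc4ccccc4)[C@@H](CN4CCCc5ccccc54)C3)cc2c1` has not yet been measured in this assay. It differs from compound 1 in one place (a group of 10 heavy atoms (9 carbon, 1 nitrogen; one six-membered non-aromatic ring with 1 hetero atom, one six-membered aromatic ring of carbon only) in place of a group of 8 heavy atoms (7 carbon, 1 nitrogen; one three-membered non-aromatic ring of carbon only, one six-membered non-aromatic ring with 1 hetero atom), on a saturated chain carbon bound to a saturated ring carbon). Going by the values given here, no pair of measured compounds differing in a single place is available, so no measured step guides this change. The expectation is a drop in solubility beyond the scatter, as expressed by the estimated step of a 4.0-fold lower number from compound 1 to compound 4 (0.61 log units; beyond the scatter). Compound 4 is accordingly estimated at 7000 nM, with a range from 2500 nM to 20000 nM.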

Compound 4, solubility: 8500 nM
For compound 4 the middle estimate is 1.2-fold (0.08 log units) below the measured one, within the range that was stated.
By their numbers in this assay, from the lowest: compounds 4, 2, 3 and 1 (each within the scatter of the next, the first and the last beyond it).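

Going by these compounds alone, compound 4 gives the first measured step at this place, on a saturated chain carbon bound to a saturated ring carbon: in this assay, 1,2,3,4-tetrahydroquinolin-1-yl in place of the group of 8 heavy atoms with its three-membered ring gives a 3.3-fold lower number from compound 1 to compound 4 (0.52 log units; beyond the scatter) on an otherwise unchanged core. The reading at this place therefore depends on the group carried there, even though the leaving and entering groups have equal counts of hydrogen-bond donors and acceptors and neither has a net charge. No measurement that bears on the cause of this step is in hand.

As far as these compounds go, it remains open whether the six-membered aromatic ring of carbon only accounts for the step. Also open, from the compounds shown here alone, is how a morpholine ring or a carboxylic acid at this place would read.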